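The source may report more compounds than this note shows. Statements on the series, on what has been measured and on what is new or still open speak of the compounds shown alone.

Measured compounds:
- Compound 1 `C=C1C[C@]23C[C@@]1(O)CC[C@H]2c1ccc(OS(=O)(=O)c2ccc(C)cc2)c(C)c1[C@@H]3Cn1cc(-c2ccc(Br)cc2)nn1`: in a functional assay on SMMC-7721 cells (Homo sapiens) for cytotoxicity, read by MTT assay, with a stated time of 4 days (a higher number here means a weaker inhibitor, a lower number a stronger inhibitor), compound 1 gives only a limit, > 20000 nM.
- Compound 2 `C=C1C[C@]23C[C@@]1(O)CC[C@H]2c1ccc(O)c(C)c1[C@@H]3Cn1cc(-c2ccc(Br)cc2)nn1`: in this assay compound 2 likewise gives only a limit, > 20000 nM.

For the measured compounds named here, compound 1 thus stands at the limit of this assay, with no number of its own; the one other value shown is a limit as well (the limit of > 20000 nM in this assay, at which 2 of the 2 values shown sit). Going by the values given here, the single measured step, a step that the two limits leave unreadable from compound 1 to compound 2, therefore cannot be read for size or direction, and it concerns the oxygen on the aromatic ring rather than the triazole substituent.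

Compound 3 `C=C1C[C@]23C[C@@]1(O)CC[C@H]2c1ccc(OS(=O)(=O)c2ccc(C)cc2)c(C)c1[C@@H]3Cn1cc(-c2ccccc2)nn1` differs from compound 1 in that triazole substituent: hydrogen in place of bromo on an aromatic carbon, 4-bromophenyl becoming phenyl. No measured step touches this position, so nothing shown points to a gain in potency from the change. The expectation for compound 3 in this assay is a step that the limit leaves unreadable from compound 1 to compound 3, which is no change beyond the scatter, most likely again reported as a limit. Compound 3 is estimated at 30000 nM, within 10000 nM to 100000 nM.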

Compound 3, half-maximal inhibitory concentration: > 20000 nM
Compound 3 gave a limit, no number (the forecaster's own chance of this, stated with the estimate: 85%); the middle value lies beyond the limit too.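

Compound 3 also reaches only a limit in this assay, so no new step can be read between compound 1 and compound 3, nor any effect of 4-bromophenyl becoming phenyl. All values shown sit at that limit: the limit of > 20000 nM in this assay, at which 3 of the 3 values shown sit.

The compounds shown leave open which structural change, if any, would bring a measurable value in this assay.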